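This account rests on a few compounds, and the source may have more. Where it says the series, first, only, none or still open, it means among the compounds named here.

Measured in a functional assay on the whole organism with Canis familiaris (Canis lupus familiaris) as the target; on this read-out higher numbers stand for an effect only at larger amounts of compound and lower numbers for an effect already at smaller amounts:
compound 1 `COC(=O)CC/C=C\CC[C@H]1C(=O)C[C@@H](O)[C@@H]1/C=C/C[C@@](C)(O)/C=C/C(C)=C(C)C` gives 0.00006 mg/kg
compound 2 `C/C=C(C)\C=C\[C@](C)(O)C/C=C/[C@H]1[C@H](O)CC(=O)[C@@H]1CC/C=C\CCC(=O)OC` gives 0.000016 mg/kg
compound 3 `C=C/C=C/[C@](C)(O)C/C=C/[C@H]1[C@H](O)CC(=O)[C@@H]1CC/C=C\CCC(=O)OC` gives 0.000007 mg/kg

Compound 3 has the lowest number of the three in this assay, and both gaps to it lie beyond the scatter. Next comes compound 4 `C/C=C(C)/C=C/[C@](C)(O)C/C=C/[C@H]1[C@H](O)CC(=O)[C@@H]1CC/C=C\CCC(=O)OC`, which remains unmeasured. The change from compound 3 is 1-methylprop-1-en-1-yl in place of vinyl on a double-bonded chain carbon bound to a double-bonded chain carbon, with 1-methylprop-1-en-1-yl in place of vinyl on a double-bonded chain carbon bound to a double-bonded chain carbon.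

The closest evidence is the opposite exchange, vinyl in place of 1-methylprop-1-en-1-yl, seen as a 2.3-fold lower number from compound 2 to compound 3 (0.36 log units; beyond the scatter). The neighbouring steps, a 3.8-fold lower number from compound 1 to compound 2 (0.57 log units; beyond the scatter) and an 8.6-fold lower number from compound 1 to compound 3 (0.93 log units; beyond the scatter), run the same way: across these three compounds, the number falls as the group becomes smaller, and none goes against this. Within the data shown here, only three compounds support that trend, so it is a thin basis. A modest rise of about the size of the opposite exchange is therefore expected, rather than no change.

The expected move is a 2.6-fold higher number from compound 3 to compound 4 (0.41 log units; beyond the scatter), a modest step toward a higher number. Among the measured compounds shown here, for compound 4 the estimate is 0.000018 mg/kg, with an expected range from 0.000006 mg/kg to 0.00006 mg/kg (kept wide, given the single direct precedent).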

Compound 4, dose for half-maximal effect: 0.000003 mg/kg
The estimate for compound 4 lay 6.0-fold (0.78 log units) above the measured number; the whole stated range lies above it.
By their numbers in this assay, from the lowest: compound 4; then compound 3; then compound 2; then compound 1.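

In this assay, compound 4 goes against the earlier fall in number with a smaller group: exchanging vinyl for 1-methylprop-1-en-1-yl on a double-bonded chain carbon bound to a double-bonded chain carbon gives a 2.3-fold lower number from compound 3 to compound 4 (0.37 log units; beyond the scatter). With the atoms and bonds unchanged there is still a 5.3-fold lower number from compound 2 to compound 4 (0.73 log units; beyond the scatter), so the gap can be placed on the geometry of that double bond, drawn Z in compound 2 and E in compound 4, due to this: the fact that compounds 2 and 4 differ only in the configuration as drawn. Against the 1,2-dimethylprop-1-en-1-yl group, the same position now shows a 20-fold lower number from compound 1 to compound 4 (1.30 log units; beyond the scatter), the widest step in the series, so the size of the group alone does not set the order of these compounds, and double-bond geometry has to be read together with it.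

Still open, on these data alone, is how a longer chain such as a hex-1-en-1-yl group, or an amine carried on the chain at this place, would read, and whether the drawn geometry would count as much there. Also open, as far as these compounds go, is whether compound 4 keeps its place ahead of compound 3 in any read-out other than this assay.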